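The source may report more compounds than this note shows. Statements on the series, on what has been measured and on what is new or still open speak of the compounds shown alone.

Measured compounds:
- compound 1, `CC1=C(/C=C/C(=O)/C=C/c2ccc(C)cc2)C(C)(C)CCC1`: in a functional assay on MCF7 cells (Homo sapiens) for cytotoxicity, read by sulforhodamine B assay, with a stated time of 48 h (on this read-out lower numbers stand for stronger inhibition and higher numbers for weaker inhibition), compound 1 gives 23800 nM
- compound 2, `CC1=C(/C=C/C(=O)/C=C/c2ccccc2Cl)C(C)(C)CCC1`: in this assay compound 2 gives 54600 nM

Within the data shown here, compound 2 stands at the highest of the two numbers, meaning the weaker of the two in this assay; its only neighbour is compound 1, and the step between them, a 2.3-fold higher number from compound 1 to compound 2 (0.36 log units; beyond the scatter), reaches beyond the usual scatter.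

Compound 3, `CC1=C(/C=C/C(=O)/C=C/c2ccccc2[N+](=O)[O-])C(C)(C)CCC1`, has not yet been measured in this assay. It differs from compound 2 in one place: nitro in place of chloro on an aromatic carbon. No measured step exchanges one small group for another on the same aromatic carbon; the single step shown, a 2.3-fold higher number from compound 1 to compound 2 (0.36 log units; beyond the scatter), changed both the group and its position at once and was modest. Among the measured compounds shown here, with no direct precedent, the expectation is that compound 3 stays close to compound 2, with the step from compound 2 to compound 3 expected to be a 1.1-fold higher number from compound 2 to compound 3 (0.04 log units; within the scatter), not clearly beyond the scatter in either direction. Compound 3 is therefore expected to give about 60000 nM in this assay, within a range of 20000 nM to 180000 nM.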

Compound 3, half-maximal inhibitory concentration: 10100 nM
Compound 3: the middle estimate sits 5.9-fold (0.77 log units) above what was measured; measured number below the stated range.
By their numbers in this assay, from the lowest: compound 3; then compound 1; then compound 2.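

In this assay the exchange of chloro for nitro on the same aromatic carbon, ortho to a large group, gives a 5.4-fold lower number from compound 2 to compound 3 (0.73 log units; beyond the scatter) and so shows that the group held at this carbon can by itself shift the result, something the earlier pair could not show when group and position changed together. The lower number means stronger inhibition here, so nitro does better than chloro at this carbon, although this rests on a single pair of compounds. The change replaces one chlorine atom with three heavy atoms, one nitrogen and two oxygen, and adds two hydrogen-bond acceptors, but no measurement is available to tie the step to any of these differences.

The compounds shown leave open whether another group at this carbon, such as an amine, a methoxy group or a carboxylic acid, would lower the number further or raise it. They also leave open whether nitro would give a step of similar size on a different carbon of the same aromatic ring.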